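The source may hold more compounds than are shown below. What is called first, only, known or untested is meant among the compounds shown, and "the series" means these compounds.

Working notes on the series, a physicochemical assay for lipophilicity, read by HPLC, tested at 5 mM; on this read-out lower numbers stand for lower lipophilicity and higher numbers for higher lipophilicity.

Three compounds have numbers. Compound 1 `CC(Oc1ccc(Oc2ccc(Cl)cc2)cc1)C(=O)Cn1nnc(-c2ccccc2)n1` gives 6; compound 2 `CC(Oc1ccc(Oc2ccc(Cl)cc2)cc1)C(=O)Cn1nnc(-c2ccc(Cl)cc2)n1` gives 6.8; compound 3 `CCCCCCCCc1ccc(OC(C)C(=O)Cn2nnc(-c3ccc(C(=O)O)cc3)n2)cc1` gives 5.9. Compound 3 is the lowest of the three, within the scatter of compound 1 and beyond it only against compound 2. Within the data shown here, the one counted step, a number 0.80 log units higher from compound 1 to compound 2 (beyond the scatter), concerns a chloro for hydrogen and does not bear on the change now in view.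

Compound 4 `CC(Oc1ccc(Oc2ccc(Cl)cc2)cc1)C(=O)Cn1nnc(-c2ccc(C(=O)O)cc2)n1` is compound 3 with 4-chlorophenoxy in place of octyl on an aromatic carbon. Among the measured compounds shown here, no measured pair shows this exchange, so the expectation rests on compound 3 alone, with 5.9 as anchor and a step estimated as a number 0.20 log units lower from compound 3 to compound 4 (within the scatter), small in either direction. For compound 4 the estimate in this assay is 5.7, range 5 to 6.4.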

Compound 4, partition coefficient: 3.3
Estimate against measurement, compound 4: 2.40 log units above; measured number outside the range, below it.
By their numbers in this assay, from the lowest: compound 4; then compounds 3 and 1 (each within the scatter of the next); then compound 2.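

In this assay the site carrying octyl is not indifferent to the exchange: 4-chlorophenoxy in place of octyl on an aromatic carbon gives a number 2.60 log units lower from compound 3 to compound 4 (beyond the scatter) and the step is large. On the other aromatic carbon, carboxy in place of chloro gives a number 3.50 log units lower from compound 2 to compound 4 (beyond the scatter) and carboxy in place of hydrogen gives a number 2.70 log units lower from compound 1 to compound 4 (beyond the scatter), so a position that had shown only a modest step with chloro also carries large ones. Nothing on hand accounts for these steps.

The compounds shown do not tell whether the octyl exchange would be as large without carboxy. Also open, going by these compounds, is how an amine on that aromatic carbon, or a shorter chain in place of octyl, would read.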